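Same Kind of Chloro Step on a Second Core

A few compounds are considered here, and "the series" means these few. Any claim that something is new, unique, unknown or untested is made for them only; others in the source may bear on it.

Three compounds have been measured in a functional assay on MCF7 cells (Homo sapiens) for inhibition, read by MTT assay, with a stated time of 48 h, tested at 10 uM; on this read-out lower numbers stand for less inhibition of growth and higher numbers for more inhibition of growth at the one concentration tested:

Compound 1, `Cc1oc2c([C@H]3CCN(C)C[C@H]3O)c(O)cc(O)c2c(=O)c1C(O)c1cccc(Cl)c1`: 5%
Compound 2, `Cc1oc2c([C@H]3CCN(C)C[C@H]3O)c(O)cc(O)c2c(=O)c1C(O)c1cccc(Cl)c1Cl`: 7%
Compound 3, `CN1CC[C@H](c2c(O)cc(O)c3c(=O)cc(/C=C/c4ccccc4)oc23)[C@H](O)C1`: 8%

All three numbers lie close together, and none of the compounds can be set apart from the others on this read-out. Compound 1 and compound 2 differ in one place, (chloro in place of hydrogen on an aromatic carbon), and this change made a number 2 percentage points higher from compound 1 to compound 2 (within the scatter). How the core of compound 3 differs from the core of compound 1 is not broken down here; their two values are within the scatter of each other.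

Compound 4, `CN1CC[C@H](c2c(O)cc(O)c3c(=O)cc(/C=C/c4ccc(Cl)cc4)oc23)[C@H](O)C1`, has not yet been measured. It differs from compound 3 in one place, (chloro in place of hydrogen on an aromatic carbon). This is the same kind of change as that from compound 1 to compound 2, but the surroundings differ: in compound 2 the entering chloro sits ortho to a chloro group and ortho to a large group, whereas in compound 4 it sits para to a large group, with no second chloro nearby.

Among the measured compounds shown here, with only one earlier example of this kind of change, and that one within the scatter, compound 4 is expected to show a step of about a number 2 percentage points higher from compound 3 to compound 4 (within the scatter), because the step of a number 2 percentage points higher from compound 1 to compound 2 (within the scatter) gave no sign of a large effect. Compound 4 is thus estimated at 10%, most likely between 0% and 25%.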

Compound 4, percent growth inhibition at one concentration: 10%
Compound 4: the middle estimate sits on the measured number at the digits printed, and the stated range covers the measured number.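

In this assay, chloro in place of hydrogen on an aromatic carbon gave a number 2 percentage points higher from compound 3 to compound 4 (within the scatter), and set beside the earlier case, the change reads the same on the two cores: the same change on two cores in this assay, a number 2 percentage points higher (within the scatter) from compound 1 to compound 2 and a number 2 percentage points higher (within the scatter) from compound 3 to compound 4, 0 percentage points apart, within the scatter of two such steps. Within this series, then, the step carried from one core to the other without any sign of a large effect on either core, even though the entering chloro stands in different surroundings in compound 2 and compound 4. This does not show that chloro acts on growth in the same way on both cores, or that it acts at all, since each step lies within the scatter and their agreement is an agreement between two steps that cannot be told from no change.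

The compounds shown leave open whether any other group on the phenyl ring of compound 3, such as a methoxy group, a nitrile or an amine in the place that chloro takes in compound 4, would give a step beyond the scatter. They also leave open whether a longer chain in place of the 2-phenylethenyl group would change the picture, and whether the chloro step would still read the same on such a compound.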